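Replacing a naphthyl ether in two related cores

This account rests on a few compounds, and the source may have more. Where it says the series, first, only, none or still open, it means among the compounds named here.

Measured compounds:
compound 1 `Cn1cc(-c2ccncc2)c(-c2ccc(OCc3ccc4ccccc4c3)cc2)n1` — 83.3 mL/min/kg
compound 2 `CN(C(=O)c1ccc2ncsc2c1)c1ccc(OCB2C=Cc3ccccc3N2)cc1` — 73.3 mL/min/kg
compound 3 `CN(C(=O)c1ccc2ncsc2c1)c1ccc(OCc2ccc3ccccc3c2)cc1` — 48.3 mL/min/kg

Of the compounds shown here, three have been measured in an ADME assay (liver) for metabolic stability, with Liver microsome (Rattus norvegicus) as the target, using microsomes; on this read-out lower numbers stand for slow clearance and higher numbers for fast clearance. Compound 3 and compound 2 share a core and differ in one place: a group of 10 heavy atoms (8 carbon, 1 boron, 1 nitrogen; one six-membered non-aromatic ring with 2 hetero atoms, one six-membered aromatic ring of carbon only) in place of a group of 10 heavy atoms (10 carbon; 2 six-membered aromatic rings of carbon only), on a saturated chain carbon bound to an oxygen on an aromatic ring. This change gave a 1.5-fold higher number from compound 3 to compound 2 (0.18 log units; within the scatter). Compound 1 carries a different core; how its core differs from that of compound 3 is not broken down here. In this assay compound 1 stands nearest to compound 2 and furthest from compound 3, and both gaps are within the scatter, so no order among the three can be read from these numbers.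

Compound 4 `Cn1cc(-c2ccncc2)c(-c2ccc(OCB3C=Cc4ccccc4N3)cc2)n1` has not yet been measured. It relates to compound 1 as compound 2 relates to compound 3: a group of 10 heavy atoms (8 carbon, 1 boron, 1 nitrogen; one six-membered non-aromatic ring with 2 hetero atoms, one six-membered aromatic ring of carbon only) in place of a group of 10 heavy atoms (10 carbon; 2 six-membered aromatic rings of carbon only), on a saturated chain carbon bound to an oxygen on an aromatic ring. This is the same kind of change, made on a different core. For the measured compounds named here, the only guide is the step from compound 3 to compound 2, which stayed within the scatter. On that basis the step in this assay from compound 1 to compound 4 is expected to be a 1.3-fold higher number from compound 1 to compound 4 (0.12 log units; within the scatter), a shift of similar size. For compound 4 the estimated value in this assay is 110 mL/min/kg, with a range of 60 mL/min/kg to 200 mL/min/kg.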

Compound 4, clearance: 41.7 mL/min/kg
Beside the measured number, compound 4's estimate is 2.6-fold (0.42 log units) above it; measured number below the stated range.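

In this assay, putting the group with boron and nitrogen in its non-aromatic ring in place of naphthalen-2-yl, on a saturated chain carbon bound to an oxygen on an aromatic ring, gave a 2.0-fold lower number from compound 1 to compound 4 (0.30 log units; within the scatter). For the compounds shown here, each step taken alone stays within the scatter, yet the two steps do not agree with each other: the same change on two cores in this assay, a 1.5-fold higher number (0.18 log units; within the scatter) from compound 3 to compound 2 and a 2.0-fold lower number (0.30 log units; within the scatter) from compound 1 to compound 4, 3.0-fold (0.48 log units) apart, beyond the scatter of two such steps In this series, then, the outcome of this change on the core of compound 3 did not carry over to the core of compound 1, but two matched pairs show only that the change can differ between these two cores, and they give neither a rule for any other core nor a reason for the gap.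

The compounds shown leave open how the same change would behave on a third core. They also leave open what an amine on the entering group, or a longer chain in place of the saturated chain carbon, would do in this assay.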